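This account rests on a few compounds, and the source may have more. Where it says the series, first, only, none or still open, it means among the compounds named here.

Of the compounds shown here, three with a shared core have been measured so far: compound 1 `Nc1scc(-c2cccc(C(F)(F)F)c2)c1C(=O)c1ccccc1`, compound 2 `Nc1scc(-c2cccc(F)c2)c1C(=O)c1ccccc1` and compound 3 `Nc1scc(-c2ccc(F)cc2)c1C(=O)c1ccccc1`. In a functional assay on CHO cells for agonist activity at adenosine receptor A1 (Homo sapiens), read by fluorescence and ERK phosphorylation, with stated times of 30 min and 1.5 h, tested at 10 uM (on this read-out higher numbers stand for a stronger effect at the one concentration tested and lower numbers for a weaker effect), compound 1 gives 59%, compound 2 gives 52% and compound 3 gives 60%. Compound 3 holds the highest of the three numbers, but its neighbours sit close: compound 1 is a single percentage point lower and compound 2 is eight points lower, and both gaps lie within the scatter, so the three compounds cannot be separated on these numbers.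

Compound 4 `Nc1scc(-c2cccc(Cl)c2)c1C(=O)c1ccccc1` has not yet been measured. It differs from compound 3 in one place: 3-chlorophenyl in place of 4-fluorophenyl on an aromatic carbon. Two earlier steps bear on this change. Swapping one group for another on the pendant ring gave a number 7 percentage points lower from compound 1 to compound 2 (within the scatter), and moving the fluorine from one ring position to another gave a number 8 percentage points higher from compound 2 to compound 3 (within the scatter). Since neither step left the scatter, no step beyond the scatter is expected here either; the estimated change is a number 3 percentage points lower from compound 3 to compound 4 (within the scatter). Compound 4 is therefore expected to give about 57% in this assay, within a range from 45% to 68%.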

Compound 4, a percentage reported as activity, at one concentration (the size of the read-out at that concentration, not a potency): 52%
Compound 4: the middle estimate sits 5 percentage points above what was measured, within the range that was stated.
By their numbers in this assay, from the lowest: compounds 2, 4, 1 and 3 (each within the scatter of the next).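

Chloro in place of fluoro gives no change at the digits printed from compound 2 to compound 4 (within the scatter) and chloro in place of trifluoromethyl gives a number 7 percentage points lower from compound 1 to compound 4 (within the scatter) in this assay so fluoro, chloro and trifluoromethyl on the phenyl group cannot be told apart on these numbers. The step from 4-fluorophenyl to 3-chlorophenyl alters both the halogen and its place on that ring, and it gives a number 8 percentage points lower from compound 3 to compound 4 (within the scatter) so this double change also leaves the number inside the usual spread of repeat measurements. Nothing available here accounts for these small differences.

From the compounds shown here alone, whether an amine, a carboxylic acid or a longer chain on this phenyl group would give a step beyond the scatter stays open. So does the question of how 4-chlorophenyl would compare with 3-chlorophenyl at this place on the shared core.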